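A Cyclopentyl for a Butyl on the Shared Core

The source may report more compounds than this note shows. Statements on the series, on what has been measured and on what is new or still open speak of the compounds shown alone.

Compound 1 `CCCCc1ccc(COC(=O)N[C@H]2CNC2=O)cc1`: 23 nM
Compound 2 `O=C(N[C@H]1CNC1=O)OCCCCCc1ccccc1`: 298 nM
Compound 3 `O=C(N[C@H]1CNC1=O)OCCOCC1CCCCC1`: 1280 nM

Of the compounds shown here, three with a shared core have been measured in an assay on HEK293 cells for inhibition of N-acylethanolamine-hydrolyzing acid amidase (Homo sapiens), read by fluorescence, with stated times of 10 min and 50 min; on this read-out lower numbers stand for stronger inhibition and higher numbers for weaker inhibition. Compound 1 gives the lowest number of the three, at 23 nM. Compound 2 gives 298 nM, a gap to compound 1 that lies beyond the scatter. Compound 3 gives 1280 nM, the furthest of the three from compound 1, again beyond the scatter. No two of these compounds differ in only one place, so no single step between measured compounds can be read from them; the values only show that compound 1 stands apart from compound 2 and compound 3.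

The next compound, compound 4 `O=C(N[C@H]1CNC1=O)OCc1ccc(C2CCCC2)cc1`, is compound 1 with one change: cyclopentyl in place of butyl on an aromatic carbon. The group that leaves and the group that enters are close in what is counted, and both sit on the same aromatic carbon, para to a large group. Among the compounds with values here, with no measured step of this kind to lean on, the change is expected to move this assay by no more than the scatter in either direction, so a 1.3-fold higher number from compound 1 to compound 4 (0.12 log units; within the scatter) is the expected step. Compound 4 is therefore expected to give about 30 nM in this assay, within a range of 10 nM to 90 nM.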

Compound 4, half-maximal inhibitory concentration: 71 nM
For compound 4 the middle estimate is 2.4-fold (0.37 log units) below the measured one; low and high end bracket the measured number.
By their numbers in this assay, from the lowest: compound 1; then compound 4; then compound 2; then compound 3.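

Within the data shown here, this is the first step that can be read at a single place. In this assay, cyclopentyl in place of butyl on an aromatic carbon gives a 3.1-fold higher number from compound 1 to compound 4 (0.49 log units; beyond the scatter) and so lies beyond the scatter, though the step is modest: this position responds to the form of a carbon-only group, even when neither the group that leaves nor the group that enters has any hydrogen-bond donors or acceptors. Nothing measured alongside these numbers accounts for the step.

Among these compounds, compound 2 and compound 3 each differ from compound 4 in more than one place, so no step to either of them can be read, and this single pair gives no trend across groups at this position. The compounds shown leave open whether a straight chain of another length, such as propyl or pentyl, another ring, such as cyclohexyl or phenyl, or an ether such as methoxy on the same aromatic carbon would give a number nearer to that of compound 1 or further from it.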